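A Furan-to-Pyrazole Swap and Its Expected Effect

This account rests on a few compounds, and the source may have more. Where it says the series, first, only, none or still open, it means among the compounds named here.

compound 1 `Cc1ccnc(-c2ccccc2OCC2=NCCN2)c1` — < 100000 nM
compound 2 `c1coc(-c2ccccc2OCC2=NCCN2)c1` — 1.26 nM

Going by the values given here, in a functional assay for activation of Alpha-1A adrenergic receptor (Homo sapiens), read by calcium flux (a higher number here means that more compound is needed for the effect, a lower number that less compound is needed), compound 2 gives 1.26 nM, the only number reported among the two values shown. The other value is a limit of the assay, not a number: for compound 1 the reading is the limit of < 100000 nM in this assay, at which 1 of the 2 values shown sits.

Compound 3 `c1ccc(-c2cc[nH]n2)c(OCC2=NCCN2)c1` has not yet been measured. It differs from compound 2 in one place: 1H-pyrazol-3-yl in place of furan-2-yl on an aromatic carbon. Among the compounds with values here, no step between two measured compounds covers this kind of change, so the expectation rests only on compound 2 and on the nature of the swap. A step in the direction of more compound needed is expected for compound 3, of modest size and with wide uncertainty; a result within the usual scatter of compound 2 cannot be excluded. The step from compound 2 to compound 3 is estimated at a 6.3-fold higher number from compound 2 to compound 3 (0.80 log units; beyond the scatter). Compound 3 is expected to give 8 nM in this assay, within 0.8 nM to 100 nM.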

Compound 3, half-maximal effective concentration: 5.01 nM
The estimate for compound 3 lay 1.6-fold (0.20 log units) above the measured number; the range from low to high includes it.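

Going by these compounds alone, the result gives the first readable step at this position in this assay: 1H-pyrazol-3-yl in place of furan-2-yl brings a 4.0-fold higher number from compound 2 to compound 3 (0.60 log units; beyond the scatter). It shows that a five-membered aromatic ring with 2 hetero atoms and 1 hydrogen-bond donor on this aromatic carbon still yields a measurable number, as compound 3 gives 5.01 nM. No measurement shown here bears on what lies behind this step.

Compound 1 stands at < 100000 nM, which is a limit of the assay and not a number, so steps to it cannot be read. Still open, as far as these compounds go, is whether a thiophen-2-yl or a 1-methylpyrazol-3-yl group on the same carbon would give a number nearer that of compound 2 or that of compound 3.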